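A few compounds are considered here, and "the series" means these few. Any claim that something is new, unique, unknown or untested is made for them only; others in the source may bear on it.

Of the compounds shown here, three have so far been measured in a functional assay on SMA cells (Homo sapiens) for inhibition, read by MTT assay, with a stated time of 72 h; on this read-out higher numbers stand for weaker inhibition of growth and lower numbers for stronger inhibition of growth. Compound 1 `N#C/C(=C\c1ccc([N+](=O)[O-])cc1)C(=O)c1c[nH]c2ccccc12` gives 60000 nM. Compound 2 `COc1ccc(CNC(=O)/C(C#N)=C/c2ccc[nH]2)cc1` reaches only the limit of the assay, > 50000 nM, which is a limit and not a number. Compound 3 `N#C/C(=C\c1ccc[nH]1)C(=O)NCc1ccc(Cl)c(Cl)c1` likewise stops at the limit, > 50000 nM. Compound 2 therefore stands at the limit of > 50000 nM in this assay, at which 2 of the 3 values shown sit, and nothing finer can be said about where it lies beyond that limit. The unmeasured compound 4 `COc1ccc(CNC(=O)/C(C#N)=C/c2ccc(Cl)o2)cc1` differs from compound 2 in one place: 5-chlorofuran-2-yl in place of 1H-pyrrol-2-yl on a double-bonded chain carbon bound to a double-bonded chain carbon. Among the compounds with values here, no step between two measured compounds that differ in one place is available, so no measured change of this kind can be drawn upon. Compound 4 is expected to show a step that the limit leaves unreadable from compound 2 to compound 4 that amounts to none beyond the scatter, since its parent sits at a limit and the change is a single ring exchange. The estimate for compound 4 is 60000 nM, in a range from 20000 nM to 200000 nM, and it is thought likely that compound 4 will again be reported only as a limit.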

Compound 4, concentration for 50% growth inhibition: 14000 nM
Beside the measured number, compound 4's estimate is 4.3-fold (0.63 log units) above it; the measured number lies below the stated range.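

In this assay, within the data shown here, the exchange of 1H-pyrrol-2-yl for 5-chlorofuran-2-yl on a double-bonded chain carbon bound to a double-bonded chain carbon gives an at least 3.5-fold lower number from compound 2 to compound 4 (0.55 log units; beyond the scatter) and is the only step between measured compounds in this set. It shows that this position can bring the read-out to a measured number, as compound 4 gives 14000 nM with the rest of compound 2 unchanged. The step can be stated only as a minimum because compound 2 has no number of its own, and its value is a limit: the limit of > 50000 nM in this assay, at which 2 of the 4 values shown sit.

The exchange alters the ring's hetero atom and adds chlorine in one move, so the compounds shown do not separate the two. A plain furan-2-yl or a 5-chloro-1H-pyrrol-2-yl at this place would tell them apart.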